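Trimethoxyphenyl thiazole amides: migration in breast cancer cells

The compounds below may be only part of what the source reports. "The series", "measured", "known", "first", "only" and "open" are said of these compounds alone.

Measured compounds:
- compound 1, `COc1cc(-c2csc(NC(=O)c3ccccc3)n2)cc(OC)c1OC`; compound 1 gives > 50000 nM, which is a limit of the assay.
- compound 2, `COc1cccc(C(=O)Nc2nc(-c3cc(OC)c(OC)c(OC)c3)cs2)c1`; compound 2 gives 14000 nM.
- compound 3, `COc1ccc(C(=O)N(C)c2nc(-c3cc(OC)c(OC)c(OC)c3)cs2)cc1`; compound 3 gives 312 nM.

All three values come from a functional assay on MDA-MB-231 cells (Homo sapiens), read by microscopy and transwell migration, with a stated time of 24 h; a lower number here means a stronger inhibitor, a higher number a weaker inhibitor. The first measured step is methoxy in place of hydrogen on an aromatic carbon, and it gives an at least 3.5-fold lower number from compound 1 to compound 2 (0.55 log units; beyond the scatter); the starting point is the limit (the limit of > 50000 nM in this assay, at which 1 of the 3 values shown sits), so the true size of that step is not known, only its floor. Compound 3 carries a different amide and a methyl on the amide nitrogen; the difference between the core of compound 3 and the core of compound 1 is not broken down here. The values of compound 2 and compound 3 show that compound 3 gives the lower number of the two by a margin beyond the scatter.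

Compound 4, `COc1ccc(C(=O)N(C)c2nc(-c3cc(OC)c(OC)c(OC)c3)cs2)cc1OC`, is not yet measured. It differs from compound 3 by methoxy in place of hydrogen on an aromatic carbon. For the measured compounds named here, this is the same kind of change as the one from compound 1 to compound 2, but the place is not identical: in compound 4 the entering methoxy sits ortho to a methoxy group as well as meta to a large group, whereas in compound 2 it sits only meta to a large group. The size of the earlier step is a floor rather than a number, and it was taken from the limit. A smaller step is expected here, a 1.7-fold lower number from compound 3 to compound 4 (0.24 log units; within the scatter), resting on compound 3 at 312 nM already standing far below the others. Compound 4 is expected to give about 180 nM, with a range of 60 nM to 550 nM.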

Compound 4, half-maximal inhibitory concentration: > 25000 nM
Compound 4: only a limit was reported; the forecaster's own chance of this, stated with the estimate: 1%; middle value at least 130-fold (2.14 log units) from the limit.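

In this assay, methoxy in place of hydrogen on an aromatic carbon does not carry over from one core to the other, and the two steps run in opposite directions: the same change on two cores in this assay, an at least 3.5-fold lower number (0.55 log units; beyond the scatter) from compound 1 to compound 2 and an at least 80-fold higher number (1.90 log units; beyond the scatter) from compound 3 to compound 4, at least 280-fold (2.45 log units) apart, beyond the scatter of two such steps

On the core of compound 3 the change, 4-methoxyphenyl to 3,4-dimethoxyphenyl, gives an at least 80-fold higher number from compound 3 to compound 4 (1.90 log units; beyond the scatter), and this size is only a floor, as is that of the earlier step on the core of compound 1. Compound 4 gives > 25000 nM, which is a limit of the assay, and the two steps do not show whether the reversal goes with the place of the entering methoxy, ortho to a methoxy group in compound 4, or with the rest of the core, including the methyl on the amide nitrogen.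

Left open is how much of the low number of compound 3 belongs to that methyl and how much to the place of its single methoxy group, since the compounds shown do not separate the two. Also open, going by these compounds, is how the core of compound 3 responds when an amine, a carboxylic acid or a longer chain such as ethoxy enters at the same aromatic carbon.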